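The compounds below may be only part of what the source reports. "The series", "measured", "known", "first", "only" and "open" are said of these compounds alone.

Working notes on the series. Compound 1 `O=C(Nc1ccc(Oc2ccnc3[nH]ccc23)cc1)c1cc2cccnc2n(-c2ccc(Br)cc2)c1=O` is the parent; in a functional assay on A549 cells (Homo sapiens) for antiproliferative activity, read by MTT assay, with a stated time of 72 h (a lower number here means a stronger inhibitor, a higher number a weaker inhibitor), compound 1 gives 280 nM. Compound 2 `COc1ccc(-n2c(=O)c(C(=O)Nc3ccc(Oc4ccnc5[nH]ccc45)cc3)cc3cccnc32)cc1` carries the change (methoxy in place of bromo on an aromatic carbon); in this assay compound 2 gives 930 nM, a step of a 3.3-fold higher number from compound 1 to compound 2 (0.52 log units; beyond the scatter). Compound 3 `Cn1ccc2c(Oc3ccc(NC(=O)c4cc5cccnc5n(-c5ccc(Br)cc5)c4=O)cc3)ccnc21` differs from compound 1 by methyl in place of hydrogen on an aromatic nitrogen; in this assay compound 3 gives 680 nM, which is a 2.4-fold higher number from compound 1 to compound 3 (0.39 log units; beyond the scatter). Compound 3 and compound 2 lie within the scatter of each other.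

Compound 4 `COc1ccc(-n2c(=O)c(C(=O)Nc3ccc(Oc4ccnc5c4ccn5C)cc3)cc3cccnc32)cc1` has not yet been measured. It differs from compound 3 by methoxy in place of bromo on an aromatic carbon, the same change as that from compound 1 to compound 2, at the same place; the change occurs twice among these four compounds, and the two cores on which it is made differ by methyl in place of hydrogen on an aromatic nitrogen. Among the measured compounds shown here, the one measured instance gave a 3.3-fold higher number from compound 1 to compound 2 (0.52 log units; beyond the scatter). Compound 4 is expected to move from compound 3 by a 3.2-fold higher number from compound 3 to compound 4 (0.51 log units; beyond the scatter) in this assay, resting on the step of a 3.3-fold higher number from compound 1 to compound 2 (0.52 log units; beyond the scatter) seen in the measured pair and on the unchanged place of the substitution. The estimate for compound 4 in this assay is 2200 nM, with a likely range of 1000 nM to 5000 nM.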

Compound 4, half-maximal inhibitory concentration: 3460 nM
Compound 4: the middle estimate sits 1.6-fold (0.20 log units) below what was measured, and the stated range covers the measured number.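

In this assay the change from 4-bromophenyl to 4-methoxyphenyl gives a 5.1-fold higher number from compound 3 to compound 4 (0.71 log units; beyond the scatter), and its size carries over from the core of compound 1 to the core of compound 3: the same change on two cores in this assay, a 3.3-fold higher number (0.52 log units; beyond the scatter) from compound 1 to compound 2 and a 5.1-fold higher number (0.71 log units; beyond the scatter) from compound 3 to compound 4, 1.5-fold (0.19 log units) apart, within the scatter of two such steps. Methyl in place of hydrogen on the aromatic nitrogen gives a 3.7-fold higher number from compound 2 to compound 4 (0.57 log units; beyond the scatter) with methoxy present, and that step agrees with the one seen with bromo present: the same change on two cores in this assay, a 2.4-fold higher number (0.39 log units; beyond the scatter) from compound 1 to compound 3 and a 3.7-fold higher number (0.57 log units; beyond the scatter) from compound 2 to compound 4, 1.5-fold (0.19 log units) apart, within the scatter of two such steps. Within the scatter, the two changes therefore combine without any detectable interaction in these four compounds, but this rests on a single square of two cores and two groups and shows neither why each change raises the number nor whether the agreement extends to other cores.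

Still open, as far as these compounds go, is how an amine, a carboxylic acid or a chloro group would read at this place on the phenyl ring. Also open, from the compounds shown here alone, is whether a longer chain such as ethyl on the aromatic nitrogen would follow the step seen with methyl.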